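The compounds below may be only part of what the source reports. "The series", "measured", "known", "first", "only" and "open" are said of these compounds alone.

Measured in a functional assay on WM 266-4 cells (Homo sapiens) for inhibition, read by MTT assay, with a stated time of 24 h; a lower number here means a stronger inhibitor of growth, a higher number a weaker inhibitor of growth:
- compound 1 `COc1ccc(C2=NN(C(=O)c3ccc4c(c3)OCCO4)C(c3ccccc3F)C2)cc1` gives 3470 nM
- compound 2 `COc1ccc(C2=NN(C(=O)c3ccc4c(c3)OCCO4)C(c3ccccc3)C2)cc1` gives 2370 nM
- compound 3 `COc1ccc(C2=NN(C(=O)c3ccc4c(c3)OCCO4)C(c3cccc(F)c3)C2)cc1` gives 930 nM

Compound 1 stands at the highest number of the three: the step of a 1.5-fold lower number from compound 1 to compound 2 (0.17 log units; within the scatter) lies within the scatter, while a 3.7-fold lower number from compound 1 to compound 3 (0.57 log units; beyond the scatter) and a 2.5-fold lower number from compound 2 to compound 3 (0.41 log units; beyond the scatter) are modest steps beyond it.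

Compound 4 `O=C(c1ccc2c(c1)OCCO2)N1N=C(c2ccccc2)CC1c1ccccc1F` differs from compound 1 by hydrogen in place of methoxy on an aromatic carbon. Among the compounds with values here, none of the measured steps touches the methoxy; all three concern the fluorophenyl on the saturated ring carbon. Within the data shown here, there is therefore no measured step that bears on this change, and no direction can be read from the series. The expectation is a step of a 1.2-fold higher number from compound 1 to compound 4 (0.06 log units; within the scatter), no larger than the scatter. Compound 4 is estimated at 4000 nM, with a range of 1500 nM to 11000 nM in this assay.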

Compound 4, concentration for 50% growth inhibition: 2500 nM
Compound 4: the middle estimate sits 1.6-fold (0.20 log units) above what was measured; the range from low to high includes it.
By their numbers in this assay, from the lowest: compound 3; then compounds 2, 4 and 1 (each within the scatter of the next).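

In this assay, within the data shown here, there is a 1.4-fold lower number from compound 1 to compound 4 (0.14 log units; within the scatter), the first reading at this position, as all earlier steps concerned the fluorophenyl group. With the 2-fluorophenyl group of compound 1 in place, the change from 4-methoxyphenyl to phenyl therefore shifts growth inhibition by no more than the scatter, so the methoxy is not required to keep this level. No evidence on the cause is available.

From the compounds shown here alone, whether the same change holds alongside the 3-fluorophenyl group of compound 3 remains open. Also open, going by these compounds, is what a hydroxyl or an amine would give on that aromatic carbon.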